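The compounds below may be only part of what the source reports. "The series", "measured", "known", "first", "only" and "open" are said of these compounds alone.

Three compounds on the shared core have been put through this study, and they differ only in the group carried on the aromatic ring. Compound 1 `COc1ccc(N2CCN(CNC(=O)c3cnccn3)CC2)cc1` and compound 2 `O=C(NCN1CCN(c2ccc([N+](=O)[O-])cc2)CC1)c1cnccn1` were both entered into a functional assay on Vero cells (Chlorocebus sabaeus) for cytotoxicity, read by MTT assay (a lower number here means that less compound is tolerated, a higher number that more compound is tolerated), yet compound 1 gives "not determined" (no result reported) and compound 2 gives "not determined" (no result reported), so neither contributes a number. Compound 3 `O=C(NCN1CCN(c2ccc(F)cc2)CC1)c1cnccn1` is the only one of the three with a result. In this assay compound 3 gives > 62.5 ug/mL, which is a limit of the assay and not a measured number. Within the data shown here, compound 3 therefore stands at the limit of > 62.5 ug/mL in this assay, at which 1 of the 3 values shown sits, and with nothing to compare it against, no measured step within the set can be drawn.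

Compound 4 `O=C(NCN1CCN(c2ccc(C(F)(F)F)cc2)CC1)c1cnccn1` is the next member. The change from compound 3 to compound 4 is trifluoromethyl in place of fluoro on an aromatic carbon. Among the measured compounds shown here, no measured pair in this set carries such a change, so any expectation rests on the limit of compound 3 alone. The step from compound 3 to compound 4 in this assay is expected to be an at least 1.1-fold lower number from compound 3 to compound 4 (0.05 log units; that floor lies within the scatter), slightly toward less compound being tolerated, but not clearly beyond the scatter. Compound 4 is thus estimated at 55 ug/mL, within a range from 20 ug/mL to 150 ug/mL, with a fair chance that only a limit is again reported.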

Compound 4, half-maximal cytotoxic concentration: > 62.5 ug/mL
Compound 4 ended at the assay's limit; the forecaster's own chance of this, stated with the estimate: 55%; middle value at least 1.1-fold (0.05 log units) from the limit.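

In this assay, compound 3 and compound 4 both end at a limit and not at a number, so no step can be read between them: the limit of > 62.5 ug/mL in this assay, at which 2 of the 4 values shown sit.

The compounds shown leave open how much of either compound the cells tolerate, and whether trifluoromethyl in place of fluoro on an aromatic carbon shifts that amount at all.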